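The source may hold more compounds than are shown below. What is called first, only, known or untested is meant among the compounds shown, and "the series" means these compounds.

Compound 1, `CS(=O)(=O)c1ccc2c(c1)CCN2S(=O)(=O)c1ccc(-c2cnc(C3CC3)o2)cc1`, in a functional assay on BGC-823 cells (Homo sapiens) for inhibition, read by MTT assay, tested at 10 uM (a lower number here means less inhibition, a higher number more inhibition at the concentration tested (going by the name of the read-out)), gives 28.3%.
Compound 2, `O=[N+]([O-])c1ccc2c(c1)CCN2S(=O)(=O)c1ccc(-c2cnc(C3CC3)o2)cc1`, in this assay gives 87.5%.

Within the data shown here, compound 2 stands highest of the two numbers measured so far; its nearest neighbour is compound 1, and the step of a number 59.2 percentage points higher from compound 1 to compound 2 (beyond the scatter) lies beyond the usual scatter. Compound 3, `O=S(=O)(c1ccc(-c2cnc(C3CC3)o2)cc1)N1CCc2cc(F)ccc21`, has not yet been measured. Compared with compound 2 the change is fluoro in place of nitro on an aromatic carbon. Among the measured compounds shown here, no measured step swaps nitro for fluoro, so the only guide is the one step available, a number 59.2 percentage points higher from compound 1 to compound 2 (beyond the scatter), which shows that the group at this position can move the read-out by a large amount. Fluoro is a third group at the same place, and whether it behaves more like nitro or more like methylsulfonyl cannot be read from these two compounds. For the measured compounds named here, a drop from compound 2 is expected, since the one alternative group seen, in compound 1, gave 28.3%, but the size is uncertain. For compound 3 the expected step is a number 42.5 percentage points lower from compound 2 to compound 3 (beyond the scatter), giving an estimated value of 45%, within a range from 15% to 80%.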

Compound 3, a percentage reported as inhibition, at one concentration (the size of the read-out at that concentration, not a potency): 18.3%
The estimate for compound 3 lay 26.7 percentage points above the measured number; the range from low to high includes it.
By their numbers in this assay, from the lowest: compounds 3 and 1 (each within the scatter of the next); then compound 2.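

Within this assay, the change from nitro to fluoro brings a number 69.2 percentage points lower from compound 2 to compound 3 (beyond the scatter), so the high number of compound 2 does not come with just any replacement of methylsulfonyl at this aromatic carbon. The other step, a number 10 percentage points lower from compound 1 to compound 3 (within the scatter), shows that fluoro and methylsulfonyl cannot be told apart here, even though they are very different groups. Among these three compounds, nitro is the only group that stands apart, and this is now seen against two alternatives rather than one. Nothing available explains why nitro stands apart from the other two groups.

Still open, from the compounds shown here alone, is whether nitro is unique at this place, or whether a nitrile, a trifluoromethyl group or an amine on the same carbon could also reach the level of compound 2. Also open, going by these compounds, is how nitro would fare on another carbon of the same ring, and how compound 2 would behave over a range of concentrations, since a reading at a single concentration gives the size of the effect at that concentration and not a potency.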